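The source may hold more compounds than are shown below. What is called first, only, known or untested is meant among the compounds shown, and "the series" means these compounds.

Measured so far in an ADME assay on microsomes from liver (Homo sapiens) for metabolic stability, with a stated time of 60 min; a higher number here means that more of the compound is left, a lower number that less of the compound is left:
Compound 1 `Cc1ccc(NC(=O)C[C@H](CCC(=O)O)c2noc(-c3cc(CC(C)C)on3)c2C2CC2)c(Cl)c1` with 74%
Compound 2 `Cc1ccc(NC(=O)C[C@H](CCC(=O)O)c2noc(-c3cnc(CC(C)C)s3)c2C2CC2)c(Cl)c1` with 54%
Compound 3 `Cc1ccc(NC(=O)C[C@H](CCC(=O)O)c2noc(-c3cc(CC(C)(C)C)on3)c2C2CC2)c(Cl)c1` with 84%

Compound 3 gives 84% in this assay and sits clear of compound 2 only. Two measured steps end at it: a number 30 percentage points higher from compound 2 to compound 3 (beyond the scatter) and a number 10 percentage points higher from compound 1 to compound 3 (within the scatter) in the same read-out. The unmeasured compound 4 `CC(C)(C)Cc1cc(-c2onc([C@@H](CCC(=O)O)CC(=O)Nc3ccc(Cl)cc3Cl)c2C2CC2)no1` differs from compound 3 in one place (chloro in place of methyl on an aromatic carbon), with chloro in place of methyl on an aromatic carbon. Those two steps, and a number 20 percentage points lower from compound 1 to compound 2 (beyond the scatter) as well, change other parts of the molecule, and none of them replaces this methyl. The data therefore offer no direct guide to this swap, and the measured steps give only a sense of how far values can move in this small set. No change beyond the scatter is expected, and the estimate amounts to a number 2 percentage points lower from compound 3 to compound 4 (within the scatter) in this read-out. For compound 4 the estimated value is 82% with an expected range from 68% to 94% around it.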

Compound 4, percent of the compound remaining: 96%
Beside the measured number, compound 4's estimate is 14 percentage points below it; measured number outside the range, above it.
By their numbers in this assay, from the lowest: compound 2; then compounds 1 and 3 (each within the scatter of the next); then compound 4.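

In this assay the swap from 2-chloro-4-methylphenyl to 2,4-dichlorophenyl gives a number 12 percentage points higher from compound 3 to compound 4 (beyond the scatter) and is the only step shown at this position. Among the compounds shown here, it shows that this spot, para to a large group and meta to a chloro group, matters in this read-out: exchanging one heavy atom here moves the number beyond the scatter, which the earlier steps, all made in other parts of the molecule, could not show. No measurement at hand bears on why the number rises, so the step stands as an observation only.

From the compounds shown here alone, whether the rise is particular to chloro, or would also come with fluoro, trifluoromethyl or methoxy at this position, stays open. Also open, going by these compounds, is whether the same swap would act alike with the 2-isobutyl-1,3-thiazol-5-yl group of compound 2 in place of the 5-neopentyl-1,2-oxazol-3-yl group.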